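The source may hold more compounds than are shown below. What is called first, only, known or untested is meant among the compounds shown, and "the series" means these compounds.

Compound 1 `O/N=C(/Nc1ccc(F)c(F)c1)c1ccc2occc2c1`, 22700 nM in an assay on isolated protein for inhibition of Indoleamine 2,3-dioxygenase 1 (Homo sapiens), read by spectrophotometry; on this read-out higher numbers stand for weaker inhibition and lower numbers for stronger inhibition
Compound 2 `O/N=C(/Nc1ccc(F)c(Cl)c1)c1ccc2occc2c1`, 5200 nM
Compound 3 `O/N=C(/Nc1cccc(F)c1)c1ccc2oc(-c3ccccc3)cc2c1`, 11000 nM

Compound 1 and compound 2 share one core and differ by chloro in place of fluoro on an aromatic carbon, a change that gave a 4.4-fold lower number from compound 1 to compound 2 (0.64 log units; beyond the scatter). Compound 3 rests on another core; how the two cores differ is not broken down here. Compound 4 `O/N=C(/Nc1cccc(Cl)c1)c1ccc2oc(-c3ccccc3)cc2c1` has not been measured and differs from compound 3 by chloro in place of fluoro on an aromatic carbon. This is the same kind of change as in the earlier pair, not the same one: in compound 2 the entering chloro is ortho to a fluoro group (1 heavy atom), whereas in compound 4 it is only meta to a large group. Beside the earlier step, the estimated step in this assay is a 3.1-fold lower number from compound 3 to compound 4 (0.50 log units; beyond the scatter), expected because a 4.4-fold lower number from compound 1 to compound 2 (0.64 log units; beyond the scatter) was modest and no ortho fluoro is present here. Compound 4 is thus estimated at 3500 nM, between 1500 nM and 9000 nM.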

Compound 4, half-maximal inhibitory concentration: 900 nM
The estimate for compound 4 lay 3.9-fold (0.59 log units) above the measured number; measured number below the stated range.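

Chloro in place of fluoro again moved the number down on the second core, giving a 12-fold lower number from compound 3 to compound 4 (1.09 log units; beyond the scatter) in this assay. The direction of the change therefore carried over from one core to the other, but its size did not: the same change on two cores in this assay, a 4.4-fold lower number (0.64 log units; beyond the scatter) from compound 1 to compound 2 and a 12-fold lower number (1.09 log units; beyond the scatter) from compound 3 to compound 4, 2.8-fold (0.45 log units) apart, beyond the scatter of two such steps These two pairs do not show which feature of the cores goes with the larger step, and they give no basis for predicting the size of the step on any further core.

The compounds shown leave open whether a bromo, methyl or trifluoromethyl group in place of the chloro of compound 4 would lower the number further. As far as these compounds go, it also remains open how an amine or a carboxylic acid would fare there.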